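Branching the chain on the cyanoguanidine of compound 2

The source may report more compounds than this note shows. Statements on the series, on what has been measured and on what is new or still open speak of the compounds shown alone.

In a functional assay on the whole organism (blood, strain Wistar-Okamoto) with Rattus norvegicus as the target, with a stated time of 5 days (on this read-out higher numbers stand for an effect only at larger amounts of compound and lower numbers for an effect already at smaller amounts), compound 1 `N#CNC(=N)Nc1cccnc1` gives 50 mg/kg. Compound 2 `CCC/N=C(\NC#N)Nc1cccnc1` carries a propyl group on the double-bonded nitrogen, and in this assay compound 2 gives 20 mg/kg, the lowest of the two numbers shown; compound 1 sits at a number that differs by more than the usual scatter. Compound 3 `CCCCC(CC)C/N=C(\NC#N)Nc1cccnc1` carries a longer, branched chain at the same nitrogen, and in this assay compound 3 yields only a limit of the assay, > 50 mg/kg. Compound 4 `CC(C)/N=C(\NC#N)Nc1cccnc1` is compound 2 rearranged: isopropyl in place of propyl on a double-bonded nitrogen. For the measured compounds named here, no step between measured compounds tells how this branching acts. The step from compound 2 to compound 4 is expected to be small, a 1.3-fold higher number from compound 2 to compound 4 (0.10 log units; within the scatter). In this assay compound 4 is therefore estimated at 25 mg/kg, within a range of 10 mg/kg to 50 mg/kg.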

Compound 4, minimum effective dose: 2.5 mg/kg
The estimate for compound 4 lay 10-fold (1.00 log units) above the measured number; the whole stated range lies above it.
By their numbers in this assay, from the lowest: compound 4; then compound 2; then compound 1.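

Within this assay the step of an 8.0-fold lower number from compound 2 to compound 4 (0.90 log units; beyond the scatter) comes from a change that adds and removes no atoms: isopropyl simply takes the place of propyl on the double-bonded nitrogen. The earlier compounds shown here could not show this, since they differ in more than how the chain is joined. At this position, then, the shape of a small chain can matter as much as what it contains.

As far as these compounds go, whether a tert-butyl group or a cyclopentyl ring on the same nitrogen would lower the number further remains open. Nothing measured here explains why this rearrangement has so large an effect.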